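Swapping Isopropyl for Oxanylmethyl: Expected Clearance Shift

The source may report more compounds than this note shows. Statements on the series, on what has been measured and on what is new or still open speak of the compounds shown alone.

Compound 3 `CC(C)Cn1cc(-c2ccnc3[nH]c(C4CCN(CC(=O)N(C)C)CC4)cc23)ccc1=O` was tested in an ADME assay on cells (Hepatocyte, Rattus norvegicus) for metabolic stability (a higher number here means faster removal of the compound, a lower number slower removal), and gives 6.6 uL/min, the lowest of the two numbers recorded. Compound 2 `CC(C)n1cc(-c2ccnc3[nH]c(C4CCN(CC(=O)N(C)C)CC4)cc23)cnc1=O` gives 100 uL/min in this assay, a higher value that lies beyond the usual scatter. Compound 1 `CC(C)n1cc(-c2ccnc3[nH]c(C4CCNCC4)cc23)ccc1=O` reaches only a limit of this assay, reported as < 1 uL/min. Compound 4 `CN(C)C(=O)CN1CCC(c2cc3c(-c4ccc(=O)n(CCC5CCOCC5)c4)ccnc3[nH]2)CC1` has not yet been measured in this assay. It differs from compound 3 in one place: (oxan-4-yl)methyl in place of isopropyl on a saturated chain carbon bound to an aromatic nitrogen. Among the measured compounds shown here, no measured pair shares this change, so the direction rests on expectation alone. A modest rise in this assay is expected, toward faster removal but near the edge of the scatter. The step that this estimate implies is expected to be a 1.4-fold higher number from compound 3 to compound 4 (0.13 log units; within the scatter). Compound 4 is estimated at 9 uL/min in this assay, with a likely range from 3 uL/min to 27 uL/min.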

Compound 4, intrinsic clearance in a liver preparation (reported as CLH), per the amount of preparation that the assay uses: 14 uL/min
Estimate against measurement, compound 4: 1.6-fold (0.19 log units) below, within the range that was stated.
By their numbers in this assay, from the lowest: compound 3; then compound 4; then compound 2. At a limit, below all of these: compound 1.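

Among the compounds shown here, at this place, on a saturated chain carbon bound to an aromatic nitrogen, the only measured change is (oxan-4-yl)methyl in place of isopropyl, and in this assay it reads a 2.1-fold higher number from compound 3 to compound 4 (0.33 log units; beyond the scatter). The step is modest, so this larger group, with its six-membered non-aromatic ring, raises the number only a little. Nothing measured here gives a reason for this step. A cyclohexylmethyl group would show whether the ring oxygen counts. From the compounds shown here alone, how an amine or a carboxylic acid on this chain would read stays open.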